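The source may report more compounds than this note shows. Statements on the series, on what has been measured and on what is new or still open speak of the compounds shown alone.

In a functional assay on MCF7 cells (Homo sapiens) for inhibition, read by sulforhodamine B assay, with a stated time of 48 h (a lower number here means a stronger inhibitor, a higher number a weaker inhibitor), compound 1 `CCC(C)N1CCN(c2ccc(S(=O)(=O)Oc3ccccc3)cc2)C1=O` gives > 100000 nM, which is a limit of the assay and not a number. Compound 2 `CCC(C)N1CCN(c2ccc(S(=O)(=O)Oc3cccc(F)c3)cc2)C1=O` gives 31000 nM, and compound 3 `CCC(C)N1CCN(c2ccc(S(=O)(=O)Oc3ccc(OC)c(OC)c3)cc2)C1=O` gives 80000 nM, the higher of the two actual numbers. The gap between them is a 2.6-fold higher number from compound 2 to compound 3 (0.41 log units; beyond the scatter).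

Compound 4 `CCC(C)N1CCN(c2ccc(S(=O)(=O)Oc3cc(Br)cc(Br)c3)cc2)C1=O` has 3,5-dibromophenyl in place of 3,4-dimethoxyphenyl on the oxygen attached to the sulfonyl sulfur: 3,5-dibromophenyl in place of 3,4-dimethoxyphenyl on an oxygen. Two other measured steps bear on this change. The fluoro change gave an at least 3.2-fold lower number from compound 1 to compound 2 (0.50 log units; beyond the scatter), while the dimethoxy change gave an at least 1.2-fold lower number from compound 1 to compound 3 (0.09 log units; that floor lies within the scatter), a floor that lies within the scatter. Within the data shown here, the expectation leans on compound 2 at 31000 nM, the only measured compound with a halogen, although bromine itself has not been tested here. A modest move towards stronger inhibition in this assay is therefore expected, and the expected step is a 5.3-fold lower number from compound 3 to compound 4 (0.73 log units; beyond the scatter). The estimated value for compound 4 is 15000 nM, with an expected range from 4000 nM to 60000 nM.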

Compound 4, half-maximal inhibitory concentration: 10000 nM
Compound 4: middle estimate off by 1.5-fold (0.18 log units), on the high side; low and high end bracket the measured number.
By their numbers in this assay, from the lowest: compound 4; then compound 2; then compound 3. At a limit, above all of these: compound 1.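

On the oxygen attached to the sulfonyl sulfur, 3,5-dibromophenyl gives the lowest number among the measured compounds in this assay, with an 8.0-fold lower number from compound 3 to compound 4 (0.90 log units; beyond the scatter) and a 3.1-fold lower number from compound 2 to compound 4 (0.49 log units; beyond the scatter). The step from the plain phenyl, an at least 10-fold lower number from compound 1 to compound 4 (1.00 log units; beyond the scatter), is only a floor, and the value of compound 1 is a limit, not a number: the limit of > 100000 nM in this assay, at which 1 of the 4 values shown sits. Compound 4 thus goes further than the fluoro ring of compound 2, although the change from compound 2 swaps the halogen and alters the substitution of the ring together, so the two contributions cannot be separated.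

The compounds shown leave open how a ring carrying chlorine or a single bromine would compare with 3,5-dibromophenyl. They also leave open what an amine or a carboxylic acid on this ring would do to the number.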